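Taking the trifluoromethyl group off compound 1

A few compounds are considered here, and "the series" means these few. Any claim that something is new, unique, unknown or untested is made for them only; others in the source may bear on it.

Compound 1 `COC(=O)c1c(C)[nH]c(C)c1C(=O)c1ccccc1C(F)(F)F` gives 4840 nM
Compound 2 `COC(=O)c1c(C)[nH]c(C)c1C(=O)c1ccccc1OC(=O)c1ccccc1O` gives 3800 nM

Both compounds were tested in a functional assay with Cavia porcellus as the target (a lower number here means that less compound is needed, a higher number that more compound is needed for the effect), and their two numbers lie within the usual scatter of each other. For the measured compounds named here, compound 1 therefore stands level with the only other measured compound, and neither can be ranked ahead.

Compound 3 `COC(=O)c1c(C)[nH]c(C)c1C(=O)c1ccccc1` keeps the core of compound 1 but has hydrogen in place of trifluoromethyl on an aromatic carbon. Going by the values given here, no two measured compounds differ in only one place, so the data give no direct guide to the size of this change. Compound 1 and compound 2 both carry a group other than hydrogen at this place, which makes compound 3 a departure from both. With so little to go on, a modest move towards a higher number in this assay seems more likely than a drop, though a result within the scatter would be no surprise. The expected change is a 1.7-fold higher number from compound 1 to compound 3 (0.22 log units; within the scatter) in this estimate. For compound 3 the estimated value is 8000 nM with an expected range from 2000 nM to 30000 nM as a wide allowance.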

Compound 3, half-maximal effective concentration: 21900 nM
For compound 3 the middle estimate is 2.7-fold (0.44 log units) below the measured one; measured number inside the range.
By their numbers in this assay, from the lowest: compounds 2 and 1 (each within the scatter of the next); then compound 3.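

For the compounds shown here, replacing trifluoromethyl with hydrogen gives the first step in this set that clearly exceeds the usual scatter: in this assay there is a 4.5-fold higher number from compound 1 to compound 3 (0.66 log units; beyond the scatter). So this place on the aromatic ring, ortho to a large group, is not indifferent to what it carries: with hydrogen there, more compound is needed for the effect. Among these three compounds, the two with a group other than hydrogen at this place, compound 1 and compound 2, lie within the scatter of each other despite their very different groups, and compound 3 has the highest number. The data offer no measurement that explains why the number moves with this change.

The compounds shown leave open how little needs to sit at this place to keep the lower number, for instance whether a single chlorine atom or a methyl group would do as well as trifluoromethyl. They also leave open whether an amine or a carboxylic acid would be tolerated here, and whether either could bring the number below those of compound 1 and compound 2.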